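The source may report more compounds than this note shows. Statements on the series, on what has been measured and on what is new or still open speak of the compounds shown alone.

Within the data shown here, compound 1 `CN(O)C(=O)CCSc1nc2ccccc2s1` gives 39 nM in a functional assay for inhibition of Polyunsaturated fatty acid 5-lipoxygenase (Homo sapiens) (a lower number here means that less compound is needed, a higher number that more compound is needed for the effect), the higher of the two numbers at hand; its only neighbour, compound 2 `CN(O)C(=O)CCSc1nc2cc(Cl)ccc2s1`, gives 20 nM, and the step of a 2.0-fold lower number from compound 1 to compound 2 (0.29 log units; within the scatter) concerns a chloro group on the core, not the chain. Compound 3 `CN(O)C(=O)NCCSc1nc2ccccc2s1` differs from compound 1 by (hydroxy(methyl)carbamoyl)amino in place of hydroxy(methyl)carbamoyl on a saturated chain carbon, two bonds along the chain from a sulfur. Among the measured compounds shown here, no measured step touches this part of the molecule, so the expectation rests on compound 1 alone: a step of a 1.3-fold lower number from compound 1 to compound 3 (0.11 log units; within the scatter) of no size beyond the scatter is expected in this assay. Compound 3 is therefore estimated at 30 nM, with a range from 8 nM to 120 nM.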

Compound 3, half-maximal effective concentration: 90 nM
Estimate against measurement, compound 3: 3.0-fold (0.48 log units) below; measured number inside the range.
By their numbers in this assay, from the lowest: compounds 2 and 1 (each within the scatter of the next); then compound 3.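

Among these compounds, this is the first change on the chain rather than on the core, and in this assay it gives a 2.3-fold higher number from compound 1 to compound 3 (0.36 log units; beyond the scatter), a modest step but one beyond the scatter. The chloro step on the core stayed within the scatter, so the chain is the first place shown where a single change moves the number beyond it. Still open, from the compounds shown here alone, is how a carboxylic acid or a longer chain would read at this place, and whether chloro on the core would act the same way with (hydroxy(methyl)carbamoyl)amino on the chain. No evidence at hand explains this result.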